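The source may report more compounds than this note shows. Statements on the series, on what has been measured and on what is new or still open speak of the compounds shown alone.

Working notes on the series. Compound 1 `Cc1ccccc1CN1CCc2c(sc(NC(=O)c3ccccc3Cl)c2C(N)=O)C1` and compound 2 `NC(=O)c1c(NC(=O)c2ccccc2Cl)sc2c1CCN(Cc1c(Cl)cccc1Cl)C2` have been run in a functional assay on MKN-74 cells (Homo sapiens) for antiproliferative activity, with a stated time of 24 h; on this read-out higher numbers stand for weaker inhibition and lower numbers for stronger inhibition. For compound 1 this assay reports only a limit, > 50000 nM. Compound 2 gives 4740 nM in this assay. Within the data shown here, the single measured step, an at least 10-fold lower number from compound 1 to compound 2 (1.02 log units; beyond the scatter), rests on that limit (the limit of > 50000 nM in this assay, at which 1 of the 2 values shown sits), so its true size is only known as a lower bound.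

Compound 3 `COc1ccc(NC(=S)N2CCc3c(sc(NC(=O)c4ccccc4Cl)c3C(N)=O)C2)cc1` changes the same position that separates compound 2 from compound 1: a group of 11 heavy atoms (8 carbon, 1 nitrogen, 1 oxygen, 1 sulfur; one six-membered aromatic ring of carbon only) in place of a group of 8 heavy atoms (8 carbon; one six-membered aromatic ring of carbon only), on an amine nitrogen in a ring. The entering group is not a further substituted benzyl, so the measured step bears on compound 3 only insofar as it shows that replacing the 2-methylbenzyl at this ring nitrogen can move the number by a large amount, downward. Among the measured compounds shown here, with no measured analogue of the thiourea-type change, the expected step of an at least 3.3-fold lower number from compound 1 to compound 3 (0.52 log units; beyond the scatter) is taken as a drop beyond the scatter, but smaller than the measured one, with a real chance that the assay again returns only a limit. Compound 3 is therefore estimated at 15000 nM, within a range of 3000 nM to 60000 nM.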

Compound 3, half-maximal inhibitory concentration: 19600 nM
Estimate against measurement, compound 3: 1.3-fold (0.12 log units) below; the measured number falls inside the stated range.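

The ring nitrogen now carries a measured group that is not a substituted benzyl, and in this assay the number still falls, with an at least 2.5-fold lower number from compound 1 to compound 3 (0.40 log units; beyond the scatter). Compound 1 sits at a limit, > 50000 nM, so this step gives only a lower bound on the size of the change: the limit of > 50000 nM in this assay, at which 1 of the 3 values shown sits. The step that can be read in full is a 4.1-fold higher number from compound 2 to compound 3 (0.62 log units; beyond the scatter), which, with the other two steps, makes compound 2 the strongest of the three in this assay and shows that the group entering in compound 3 gains less here than the dichlorinated benzyl group of compound 2.

Compound 2 and compound 3 differ in both the link to the ring nitrogen and the substitution on the aromatic ring, so the compounds shown do not separate what each of these contributes to the gap. As far as these compounds go, it also stays open how this position would read with a group lacking an aromatic ring, such as a simple acetyl group, a longer chain ending in an amine, or a chain ending in a carboxylic acid.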